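The source may hold more compounds than are shown below. What is called first, only, known or untested is meant among the compounds shown, and "the series" means these compounds.

In a functional assay on MCF7 cells (Homo sapiens), read by MTT assay, with a stated time of 48 h (on this read-out lower numbers stand for stronger inhibition and higher numbers for weaker inhibition), compound 1 (`CCN(CC)CCNC(=O)c1ccc(C(CC)(CC)c2ccc(OCC(=O)C(C)(C)C)c(C)c2)n1CC`) gives 690 nM and compound 2 (`CCN(CC)CCCNC(=O)c1ccc(C(CC)(CC)c2ccc(OCC(=O)C(C)(C)C)c(C)c2)n1CC`) gives 530 nM. These two numbers lie within the scatter of each other, so compound 2 stands level with compound 1.

Compound 3 (`CC[C@@H](C)[C@H](NC(=O)c1ccc(C(CC)(CC)c2ccc(OCC(=O)C(C)(C)C)c(C)c2)n1CC)C(=O)O`) carries 1-carboxy-2-methylbutyl in place of 3-(diethylamino)propyl on an amide-type nitrogen. Among the measured compounds shown here, only one measured step bears on this change, a 1.3-fold lower number from compound 1 to compound 2 (0.11 log units; within the scatter), and it is within the scatter. For the measured compounds named here, that step keeps the diethylamino group, whereas compound 3 loses it, and no measured compound carries a carboxy group. The measured step therefore gives only weak guidance, and the expectation is tentative. The expected change is a 4.7-fold higher number from compound 2 to compound 3 (0.67 log units; beyond the scatter), towards weaker inhibition in this assay, with wide uncertainty. For compound 3 the estimated value is 2500 nM, with an expected range of 500 nM to 12000 nM.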

Compound 3, half-maximal inhibitory concentration: 160 nM
The estimate for compound 3 lay 16-fold (1.19 log units) above the measured number; measured number below the stated range.
By their numbers in this assay, from the lowest: compound 3; then compounds 2 and 1 (each within the scatter of the next).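

In this assay, replacing the basic-amine chains on the amide-type nitrogen did not cost inhibition: 1-carboxy-2-methylbutyl in place of 3-(diethylamino)propyl gives a 3.3-fold lower number from compound 2 to compound 3 (0.52 log units; beyond the scatter), and in place of 2-(diethylamino)ethyl it gives a 4.3-fold lower number from compound 1 to compound 3 (0.63 log units; beyond the scatter), both modest and beyond the scatter. Compounds 1 and 2 both carry the diethylamino group, so they could not show that this position keeps its inhibition without it, as compound 3 now does. Nothing given here explains the shift.

Because the whole chain changes at once, these compounds cannot separate the loss of the diethylamino group from the arrival of the carboxylic acid, the branched chain or the two defined stereocentres. A methyl ester in place of the carboxylic acid, or the same branched chain without a carboxy group, would bear on that, and so would the opposite configuration at the stereocentres.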